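This account rests on a few compounds, and the source may have more. Where it says the series, first, only, none or still open, it means among the compounds named here.

Compound 1, with the structure `CCOC(=O)c1sc(-c2cccc(NC(=O)c3ccc(F)cc3)c2)nc1Nc1ccc(N2CCN(C)CC2)cc1`, was tested in a functional assay on Raji cells (Homo sapiens) for antiproliferative activity, read by CCK-8 assay, with a stated time of 72 h (on this read-out lower numbers stand for stronger inhibition and higher numbers for weaker inhibition), but the outcome for compound 1 stands only as "not determined" (no result reported), so it has no measured value to set it beside other compounds. Compound 2, with the structure `CCOC(=O)c1sc(-c2cccc(NC(=O)c3ccc(C(C)(C)C)cc3)c2)nc1Nc1ccc(N2CCN(C)CC2)cc1`, is in the same position: in this assay compound 2 likewise stands only as "not determined" (no result reported). For the measured compounds named here, the only number available belongs to compound 3, with the structure `CCOC(=O)c1sc(-c2cccc(NC(=O)c3cccc(F)c3)c2)nc1Nc1ccc(N2CCN(C)CC2)cc1`; in this assay compound 3 gives 21200 nM, a weak effect on the growth of these cells. Compound 4, with the structure `CCOC(=O)c1sc(-c2cccc(NC(=O)c3ccc(C#N)cc3)c2)nc1Nc1ccc(N2CCN(C)CC2)cc1`, has not yet been measured. Its change from compound 1 is a small one at the outer edge of the molecule: cyano in place of fluoro on an aromatic carbon. Going by the values given here, with no step between measured compounds available, and with compound 1 itself lacking a number, the size of the move in this assay can only be guessed; the expectation is a step no larger than the usual scatter, in either direction. On that basis compound 4 is expected to give about 20000 nM in this assay, with a plausible range from 5000 nM to 80000 nM.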

Compound 4, half-maximal inhibitory concentration: 14000 nM
For compound 4 the middle estimate is 1.4-fold (0.15 log units) above the measured one, within the range that was stated.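

For the compounds shown here, compound 4 gives the first step that can be read at this end of the molecule: in this assay, 4-cyanophenyl in place of 3-fluorophenyl gives a 1.5-fold lower number from compound 3 to compound 4 (0.18 log units; within the scatter), and this lies within the usual scatter. Going by these compounds alone, the step changes both the group and its place on the ring, so the two compounds show only that this pair cannot be told apart in this test. No measurement at hand accounts for the result.

Within the data shown here, compound 1 and compound 2 have no number, so no step to or from either can be read, including the direct exchange of fluoro for cyano. Also open, from the compounds shown here alone, is whether a different group at this place on the ring, such as a carboxylic acid or an amine, would shift the number beyond the scatter.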